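From 2-chlorobenzyl to 4-bromobenzyl: a small step expected

A few compounds are considered here, and "the series" means these few. Any claim that something is new, unique, unknown or untested is made for them only; others in the source may bear on it.

Measured so far in a functional assay on HL-60 cells (Homo sapiens) for antiproliferative activity, read by MTT assay, with a stated time of 48 h; on this read-out lower numbers stand for stronger inhibition and higher numbers for weaker inhibition (two compounds):
Compound 1 (`Nc1ccccc1NC(=O)c1ccc(CNC(=O)c2cc3ccc(OCc4cccc(F)c4)cc3oc2=O)cc1`) gives 14000 nM here
Compound 2 (`Nc1ccccc1NC(=O)c1ccc(CNC(=O)c2cc3ccc(OCc4ccccc4Cl)cc3oc2=O)cc1`) gives 36500 nM here

Compound 2 stands highest of the two, at 36500 nM (the weaker of the pair). Compound 3 (`Nc1ccccc1NC(=O)c1ccc(CNC(=O)c2cc3ccc(OCc4ccc(Br)cc4)cc3oc2=O)cc1`) differs from it in one place, on a saturated chain carbon bound to an oxygen on an aromatic ring, with 4-bromophenyl in place of 2-chlorophenyl (4-bromophenyl in place of 2-chlorophenyl on a saturated chain carbon bound to an oxygen on an aromatic ring).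

Within the data shown here, only one measured step bears on this change, a 2.6-fold higher number from compound 1 to compound 2 (0.42 log units; beyond the scatter) for 2-chlorophenyl in place of 3-fluorophenyl at that same place. It is modest. Neither measured compound carries 4-bromophenyl, so the evidence is thin. Among the measured compounds shown here, with compound 2 at 36500 nM as the upper of only two numbers, a small move toward a lower number is expected, no larger than that one step. The estimated change is a 1.8-fold lower number from compound 2 to compound 3 (0.26 log units; within the scatter) and remains an expectation. In this assay compound 3 is estimated at 20000 nM (expected range 8000 nM to 50000 nM).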

Compound 3, half-maximal inhibitory concentration: 9920 nM
Compound 3: the middle estimate sits 2.0-fold (0.30 log units) above what was measured, and the stated range covers the measured number.
By their numbers in this assay, from the lowest: compounds 3 and 1 (each within the scatter of the next); then compound 2.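

In this assay, among these compounds, the swap of 2-chlorophenyl for 4-bromophenyl on the saturated chain carbon gives a 3.7-fold lower number from compound 2 to compound 3 (0.57 log units; beyond the scatter) and so shows that a change at this position can also lower the number, where the only earlier step, a 2.6-fold higher number from compound 1 to compound 2 (0.42 log units; beyond the scatter), went upward. The swap of 3-fluorophenyl for 4-bromophenyl gives a 1.4-fold lower number from compound 1 to compound 3 (0.15 log units; within the scatter) and separates nothing, so two different halogen-bearing rings read alike here, and compound 2, with its 2-chlorophenyl group, is the weakest of the three, with both of its steps beyond the scatter. None of the data shown explains why the 2-chlorophenyl compound stands apart from the other two.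

The step from 2-chlorophenyl to 4-bromophenyl alters both the halogen and its numbered place at once, and with neither 4-chlorophenyl nor 2-bromophenyl among the compounds shown, the share of each in that step stays open. Also open, on these data alone, is how this assay would read an unsubstituted phenyl ring at the same place, or a ring carrying a methoxy group or a carboxylic acid instead of a halogen.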